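Methoxy to ethoxy in the amino series

The compounds below may be only part of what the source reports. "The series", "measured", "known", "first", "only" and "open" are said of these compounds alone.

Measured so far in a functional assay on FM3A cells (Mus musculus) for antiproliferative activity, with a stated time of 48 h; a higher number here means a weaker inhibitor, a lower number a stronger inhibitor:
- compound 1 `Nc1ccc(/C=C/C(=O)c2ccc(Br)cc2)cc1` gives 120000 nM
- compound 2 `COc1ccc(C(=O)/C=C/c2ccc(N)cc2)cc1` gives 282000 nM

Among the measured compounds shown here, compound 2 holds the higher of the two numbers, and compound 1 is its only neighbour. The next change, to compound 3 `CCOc1ccc(C(=O)/C=C/c2ccc(N)cc2)cc1`, is methyl in place of hydrogen on a saturated chain carbon bound to an oxygen on an aromatic ring, or methoxy to ethoxy. For the measured compounds named here, the only measured step, a 2.4-fold higher number from compound 1 to compound 2 (0.37 log units; beyond the scatter), swapped bromo for methoxy and was modest. Going by the values given here, no measured step covers this smaller change, so no clear direction is expected, and the expected move is a 1.1-fold lower number from compound 2 to compound 3 (0.04 log units; within the scatter), within the scatter. For compound 3 the estimate is 260000 nM, with an expected range of 130000 nM to 500000 nM.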

Compound 3, half-maximal inhibitory concentration: 55000 nM
Beside the measured number, compound 3's estimate is 4.7-fold (0.67 log units) above it, outside the stated range (below it).
By their numbers in this assay, from the lowest: compound 3; then compound 1; then compound 2.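

In this assay the position on the saturated chain carbon bound to an oxygen on an aromatic ring responds to a single added methyl, with methoxy to ethoxy giving a 5.1-fold lower number from compound 2 to compound 3 (0.71 log units; beyond the scatter) and making compound 3 the strongest of the three. The ethoxy group also outdoes bromo, with a 2.2-fold lower number from compound 1 to compound 3 (0.34 log units; beyond the scatter) across that swap on the aromatic carbon. Nothing at hand accounts for either step.

Open, from the compounds shown here alone, is whether a longer chain such as propoxy or butoxy extends this gain. Also open, going by these compounds, is how a hydroxyl at the same aromatic carbon would compare.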